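Replacing 4-hydroxyphenyl with 3-chlorophenyl in a growth assay

A few compounds are considered here, and "the series" means these few. Any claim that something is new, unique, unknown or untested is made for them only; others in the source may bear on it.

In a functional assay on HOP-62 cells (Homo sapiens) for inhibition, read by sulforhodamine B assay (on this read-out lower numbers stand for stronger inhibition of growth and higher numbers for weaker inhibition of growth), compound 3 (`Oc1ccc(-c2ccc(-c3ccc(-c4nc5c(O)cccc5[nH]4)cc3)cc2)cc1`) gives 2410 nM. Compound 2 (`Oc1cccc2[nH]c(-c3ccc(-c4ccc(-c5ccc(OC(F)(F)F)cc5)cc4)cc3)nc12`) gives 2270 nM, and a 1.1-fold higher number from compound 2 to compound 3 (0.03 log units; within the scatter) places these two together. Compound 1 (`Oc1cccc2[nH]c(-c3ccc(-c4ccc(-c5ccc(F)cc5)cc4)cc3)nc12`) gives 8310 nM, so compound 3 sits well under compound 1 on this scale.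

Compound 4 (`Oc1cccc2[nH]c(-c3ccc(-c4ccc(-c5cccc(Cl)c5)cc4)cc3)nc12`) has 3-chlorophenyl in place of 4-hydroxyphenyl on an aromatic carbon.

Two measured steps alter the same part of the molecule. Hydroxy in place of fluoro gives a 3.4-fold lower number from compound 1 to compound 3 (0.54 log units; beyond the scatter), and trifluoromethoxy in place of fluoro gives a 3.7-fold lower number from compound 1 to compound 2 (0.56 log units; beyond the scatter). Both are modest. Among the measured compounds shown here, no measured compound carries chlorine, so these steps offer only a rough scale. A modest rise in the number is expected in this assay, landing among the values of the three measured compounds.

The estimated change is a 1.7-fold higher number from compound 3 to compound 4 (0.22 log units; within the scatter). For compound 4 the expected value is 4000 nM, with an estimated range from 1500 nM to 11000 nM.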

Compound 4, concentration for 50% growth inhibition: 2260 nM
Compound 4: the middle estimate sits 1.8-fold (0.25 log units) above what was measured, and the stated range covers the measured number.
By their numbers in this assay, from the lowest: compounds 4, 2 and 3 (each within the scatter of the next); then compound 1.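

In this assay 3-chlorophenyl in place of 4-hydroxyphenyl gives a 1.1-fold lower number from compound 3 to compound 4 (0.03 log units; within the scatter) and in place of 4-(trifluoromethoxy)phenyl gives a 1.0-fold lower number from compound 2 to compound 4 (0.00 log units; within the scatter) so neither swap can be told apart from repeat-measurement noise. Until now every end ring carried its group in the 4-position, and 3-chlorophenyl, with 0 hydrogen-bond donors and 0 hydrogen-bond acceptors, shows that a group named in the 3-position can read the same as these. In place of 4-fluorophenyl it gives a 3.7-fold lower number from compound 1 to compound 4 (0.57 log units; beyond the scatter) and this leaves compound 1 standing apart from the other three compounds.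

No measured evidence here speaks to why these groups read alike. On these data alone, whether an amine or a carboxylic acid on this end ring would leave the number level remains open.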